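The source may hold more compounds than are shown below. What is called first, only, known or untested is meant among the compounds shown, and "the series" means these compounds.

Compound 1, `NC(=O)[C@@H]1CCCN1C(=O)CCCCCCN1CCN(c2ccccc2-c2ccccc2)CC1`: 18 nM
Compound 2, `NC(=O)[C@@H]1Cc2ccccc2CN1C(=O)CCCCCN1CCN(c2ccccc2-c2ccccc2)CC1`: 10 nM
Compound 3, `CC(C)c1ccccc1N1CCN(CCCCCCC(=O)N2CCC[C@H]2C(=O)N2CCOCC2)CC1`: 135 nM

All three were tested in an assay on HEK293 cells for displacement of a labelled ligand from 5-hydroxytryptamine receptor 7 (Homo sapiens), with a stated time of 1 h; on this read-out lower numbers stand for stronger inhibition and higher numbers for weaker inhibition. In this assay compound 1 gives 18 nM, the second highest of the three numbers. Compound 2 gives 10 nM, which lies within the usual scatter of the number for compound 1, so the two cannot be told apart. For the measured compounds named here, compound 3 gives 135 nM, a clearly higher number than that of compound 1, beyond the scatter; as compound 3 differs from compound 1 in more than one place, the pair shows only that its number is higher.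

Compound 4, `O=C([C@@H]1CCCN1C(=O)CCCCCCN1CCN(c2ccccc2-c2ccccc2)CC1)N1CCCCC1`, has not yet been measured. It differs from compound 1 in one place: piperidin-1-yl in place of amino on a carbonyl carbon. Going by the values given here, no measured pair isolates this change, so any expectation rests on thin ground. Compound 3, which also carries a cyclic tertiary amide, gives 135 nM, but it differs from compound 1 elsewhere as well, so it is at best a loose hint. The step from compound 1 to compound 4 is expected to be a modest one towards a higher number, a 1.9-fold higher number from compound 1 to compound 4 (0.29 log units; within the scatter), although a step within the scatter would not surprise. Compound 4 is therefore estimated at 35 nM, with a range from 10 nM to 120 nM.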

Compound 4, inhibition constant: 15 nM
Compound 4: middle estimate off by 2.3-fold (0.37 log units), on the high side; low and high end bracket the measured number.
By their numbers in this assay, from the lowest: compounds 2, 4 and 1 (each within the scatter of the next); then compound 3.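

In this assay, for the compounds shown here, the exchange of amino for piperidin-1-yl on a carbonyl carbon gives a 1.2-fold lower number from compound 1 to compound 4 (0.08 log units; within the scatter) and is the first step here that isolates a change at this position. The carbamoyl group of compound 1 can thus be replaced by (piperidin-1-yl)carbonyl, which removes a hydrogen-bond donor and adds a six-membered non-aromatic ring, and the read-out does not tell the two compounds apart. No evidence is at hand on why these two compounds cannot be told apart.

This single step does not show how far the result extends, since it leaves open whether other groups on the same carbonyl carbon, such as methylamino, dimethylamino, a larger ring such as azepan-1-yl, or a hydroxyl group that would give a carboxylic acid, would also stay within the scatter of compound 1. It also leaves open whether the same exchange would read the same way on the core of compound 2, which carries the same carbamoyl group on a different ring and a shorter chain.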